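A few compounds are considered here, and "the series" means these few. Any claim that something is new, unique, unknown or untested is made for them only; others in the source may bear on it.

Measured so far:
compound 1, `O=C(C1CCOCC1)N1N=CCC1c1ccccc1`: > 1.5 h
compound 2, `CC(C)(C)C(=O)N1N=CCC1C1CCCCC1`: 0.0967 h
compound 3, `CC(C)(C)C(=O)N1N=CCC1c1ccc(Cl)cc1`: 0.433 h

In an ADME assay on microsomes (Homo sapiens) for metabolic stability (on this read-out lower numbers stand for a shorter-lived compound and higher numbers for a longer-lived compound), compound 1 gives only a limit, > 1.5 h, not a number. Among the values shown, compound 1 is the one that sits at the limit of > 1.5 h in this assay, at which 1 of the 3 values shown sits. Compound 2 gives 0.0967 h in this assay, a low number on this read-out. Compound 3 gives 0.433 h in this assay, also a low number. Within the data shown here, compound 2 and compound 3 each differ from compound 1 in more than one place, so no single step connects either of them to compound 1, and nothing beyond their two values can be read from those pairs.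

Compound 4, `CC(C)(CO)C(=O)N1N=CCC1c1ccccc1`, is not yet measured in this assay. It differs from compound 1 by 1-(hydroxymethyl)-1-methylethyl in place of oxan-4-yl on a carbonyl carbon. Among the measured compounds shown here, no measured step covers this change. The entering group is a branched acyl substituent with a hydroxyl, resembling the branched acyl groups of compound 2 and compound 3, both of which gave low numbers; the aromatic part of compound 4 is that of compound 1. A downward step of moderate size, beyond the usual scatter, is expected. For compound 4 the estimate in this assay is 0.8 h, within 0.3 h to 2 h. The expected step is an at least 1.8-fold lower number from compound 1 to compound 4 (0.27 log units; that floor lies within the scatter).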

Compound 4, half-life: > 1.5 h
Compound 4: only a limit was reported (the forecaster's own chance of this, stated with the estimate: 25%); middle value at least 1.8-fold (0.27 log units) from the limit.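

In this assay compound 4 gives only a limit, > 1.5 h, not a number. Compound 1 is also reported only as a limit, so no step between compound 1 and compound 4 can be read: the limit of > 1.5 h in this assay, at which 2 of the 4 values shown sit.

The compounds shown leave open whether 1-(hydroxymethyl)-1-methylethyl in place of oxan-4-yl changes the half-life at all.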